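The source may report more compounds than this note shows. Statements on the series, on what has been measured and on what is new or still open speak of the compounds shown alone.

Measured so far:
compound 1 `N[C@@H](COP(=O)(O)OCCCOC(=O)CCc1ccccc1OCCCCCCOc1ccccc1)C(=O)O`: 20.7% in an assay on cells for agonist activity at probable G-protein coupled receptor 34 (Mus musculus), with a stated time of 1 h; a higher number here means a larger maximal response, a lower number a smaller maximal response
compound 2 `N[C@@H](COP(=O)(O)OCCCOC(=O)CCc1ccccc1OCc1cccc(Cc2ccccc2)c1)C(=O)O`: 14.5% in this assay
compound 3 `Cc1cccc(Oc2cccc(COc3ccccc3CCC(=O)OCCCOP(=O)(O)OC[C@H](N)C(=O)O)c2)c1`: 21.3% in this assay

Compound 2 carries the lowest of the three numbers, though compound 1, the nearest, and compound 3, the furthest, both lie within the scatter of it. Compound 4 `N[C@@H](COP(=O)(O)OCCCOC(=O)CCc1ccccc1OCc1cccc(Oc2ccc(Cl)cc2)c1)C(=O)O` is not yet measured and differs from compound 2 in one place: 4-chlorophenoxy in place of benzyl on an aromatic carbon. Among the compounds with values here, the one measured step that bears on this is a number 6.8 percentage points higher from compound 2 to compound 3 (within the scatter), where 3-methylphenoxy replaced benzyl on an aromatic carbon, a change of the same kind. Since that step stayed within the scatter, no step beyond the scatter is expected in this assay here either; the estimated step is a number 4.5 percentage points higher from compound 2 to compound 4 (within the scatter). Compound 4 is estimated at 19%, with a range from 10% to 28%.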

Compound 4, largest response reached (Emax), in percent of the reference or control that the assay uses: 17.8%
Beside the measured number, compound 4's estimate is 1.2 percentage points above it; the measured number falls inside the stated range.
By their numbers in this assay, from the lowest: compounds 2, 4, 1 and 3 (each within the scatter of the next).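

In this assay the change to 4-chlorophenoxy in place of benzyl gives a number 3.3 percentage points higher from compound 2 to compound 4 (within the scatter), so a second substituted phenoxy group on this aromatic carbon also leaves the maximal response within the scatter. Exchanging the group on the oxygen gives a number 3.5 percentage points lower from compound 3 to compound 4 (within the scatter), so 4-chlorophenyl and 3-methylphenyl cannot be told apart here. No data on hand offer an explanation for these small steps.

Still open, from the compounds shown here alone, is whether an amine or a carboxylic acid on the phenoxy ring, or a longer alkyl chain in its place, would move the maximal response beyond the scatter.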